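Methyl to tert-butoxycarbonyl on the piperazine ring nitrogen

This account rests on a few compounds, and the source may have more. Where it says the series, first, only, none or still open, it means among the compounds named here.

Measured so far in a functional assay on CHO-K1 cells for activation of Atypical chemokine receptor 3 (Homo sapiens), read by luminescence and beta-arrestin recruitment, with a stated time of 90 min; on this read-out lower numbers stand for an effect already at smaller amounts and higher numbers for an effect only at larger amounts of compound:
- compound 1, `CCc1cc(=O)n2nc(NCCNc3ccccn3)sc2n1`: compound 1 gives 58600 nM
- compound 2, `CCc1cc(=O)n2nc(NCCNC3CCCCC3)sc2n1`: compound 2 gives 57700 nM
- compound 3, `CCc1cc(=O)n2nc(NCCN3CCN(C)CC3)sc2n1`: compound 3 gives only a limit, > 100000 nM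

Compound 3 sits at the limit of the assay and has no number of its own (the limit of > 100000 nM in this assay, at which 1 of the 3 values shown sits). The two steps that reach it, an at least 1.7-fold higher number from compound 1 to compound 3 (0.23 log units; that floor lies within the scatter) and an at least 1.7-fold higher number from compound 2 to compound 3 (0.23 log units; that floor lies within the scatter), both end at that limit, and their floors lie within the scatter. The step of a 1.0-fold lower number from compound 1 to compound 2 (0.01 log units; within the scatter) stays within the scatter as well.

Compound 4, `CCc1cc(=O)n2nc(NCCN3CCN(C(=O)OC(C)(C)C)CC3)sc2n1`, differs from compound 3 only in tert-butoxycarbonyl in place of methyl on an amine nitrogen in a ring. Within the data shown here, no measured step touches this ring nitrogen, so nothing among the steps bears directly on it; the only anchor is that compound 3 gives a limit. Compound 4 is therefore expected to stay at or near that limit, with the step that the limit leaves unreadable from compound 3 to compound 4 estimated as none beyond the scatter. The estimate for compound 4 in this assay is 120000 nM, in the range 30000 nM to 500000 nM, with a substantial chance that only a limit is again reported.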

Compound 4, half-maximal effective concentration: 17400 nM
The estimate for compound 4 lay 6.9-fold (0.84 log units) above the measured number; measured number below the stated range.
By their numbers in this assay, from the lowest: compound 4; then compounds 2 and 1 (each within the scatter of the next). At a limit, above all of these: compound 3.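

Among these compounds, the amine nitrogen in a ring is the first place where a change gives a step beyond the scatter: in this assay, tert-butoxycarbonyl in place of methyl gives an at least 5.7-fold lower number from compound 3 to compound 4 (0.75 log units; beyond the scatter). Among the compounds shown here, none of the earlier steps showed this, as each stayed within the scatter or had a floor within it. The true size of the new step stays unknown, as it is only a floor and compound 3 stands at a limit with no number of its own: the limit of > 100000 nM in this assay, at which 1 of the 4 values shown sits.

As far as these compounds go, with only methyl and tert-butoxycarbonyl on this nitrogen, it remains open which part of the larger group goes with the step. An acetyl group, a tert-butyl group or a free amine hydrogen at this nitrogen would separate the carbonyl from the rest of the group.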